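Fluoro to Trifluoromethyl on the Aryl Ring: An Expected Step

The compounds below may be only part of what the source reports. "The series", "measured", "known", "first", "only" and "open" are said of these compounds alone.

Measured compounds:
Compound 1 `CSc1nc(-c2ccc(S(N)(=O)=O)cc2)n(-c2ccc(Cl)cc2)n1` in a functional assay on PC-3 cells (Homo sapiens) for antiproliferative activity, read by MTT assay, with a stated time of 72 h (a higher number here means a weaker inhibitor, a lower number a stronger inhibitor), gives 37500 nM.
Compound 2 `CC(=O)Oc1ccc(/C=C/C(=O)OCCSc2nc(-c3ccc(S(C)(=O)=O)cc3)n(-c3ccc(F)cc3)n2)cc1OC(C)=O` in this assay gives 15700 nM.

Of the two measured compounds, compound 2 has the lower number; the number of compound 1 lies beyond the scatter above it. Compound 3 `CC(=O)Oc1ccc(/C=C/C(=O)OCCSc2nc(-c3ccc(S(C)(=O)=O)cc3)n(-c3ccc(C(F)(F)F)cc3)n2)cc1OC(C)=O` differs from compound 2 by one change: trifluoromethyl in place of fluoro on an aromatic carbon. Going by the values given here, no measured pair shows this change, so its size is unknown here. The step from compound 2 is expected to be small, within the scatter or slightly toward a lower number, as a 1.3-fold lower number from compound 2 to compound 3 (0.12 log units; within the scatter). Compound 3 is therefore estimated at 12000 nM, between 5000 nM and 30000 nM.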

Compound 3, half-maximal inhibitory concentration: 14500 nM
The estimate for compound 3 lay 1.2-fold (0.08 log units) below the measured number, and the stated range covers the measured number.
By their numbers in this assay, from the lowest: compounds 3 and 2 (each within the scatter of the next); then compound 1.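

Trifluoromethyl in place of fluoro on an aromatic carbon, para to a large group, gives in this assay a 1.1-fold lower number from compound 2 to compound 3 (0.03 log units; within the scatter). This first measured pair for the change shows that, with compound 2 as the starting point, this position takes the larger group without a step beyond the scatter. Nothing measured here offers a reason for this result.

Going by these compounds, whether an amine, a carboxylic acid or a methoxy group at this position would read differently remains open. So does whether the same change would behave alike on the core of compound 1.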